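Salicylate esters of a bicyclic diol: rat plasma half-life

The compounds below may be only part of what the source reports. "The series", "measured", "known", "first", "only" and "open" are said of these compounds alone.

Measured so far:
compound 1 `CC(=O)Oc1ccccc1C(=O)O[C@H]1CO[C@H]2[C@@H]1OC[C@H]2O` — 0.055 h
compound 2 `CC(=O)Oc1ccccc1C(=O)O[C@H]1CO[C@H]2[C@@H]1OC[C@H]2OC(=O)c1ccc(C)cc1` — 0.105 h

Within the data shown here, in an ADME assay on a cell-free system (plasma, Homo sapiens) for metabolic stability, with Plasma (Rattus norvegicus) as the target, read by HPLC, at pH 7.4 (on this read-out higher numbers stand for a longer-lived compound and lower numbers for a shorter-lived compound), compound 2 gives the higher of the two numbers, but the only step, a 1.9-fold higher number from compound 1 to compound 2 (0.28 log units; within the scatter), does not separate it from compound 1. Compound 3 `CC(=O)Oc1ccccc1C(=O)O[C@H]1CO[C@H]2[C@@H]1OC[C@H]2OC(=O)CCO[N+](=O)[O-]` differs from compound 2 by 2-(nitrooxy)ethyl in place of 4-methylphenyl on a carbonyl carbon. No measured step changes the group on this carbonyl carbon, so nothing shown bears on it directly. With no guide, a step beyond the scatter is not expected; compound 3 is estimated at 0.08 h (range 0.03 h to 0.2 h), a change of a 1.3-fold lower number from compound 2 to compound 3 (0.12 log units; within the scatter).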

Compound 3, half-life: 0.065 h
The estimate for compound 3 lay 1.2-fold (0.09 log units) above the measured number; measured number inside the range.
By their numbers in this assay, from the lowest: compounds 1, 3 and 2 (each within the scatter of the next).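

With this assay, this carbonyl carbon now has a second group to compare: 2-(nitrooxy)ethyl in place of 4-methylphenyl gives a 1.6-fold lower number from compound 2 to compound 3 (0.21 log units; within the scatter). Against the hydrogen on the oxygen in compound 1, (2-(nitrooxy)ethyl)carbonyl gives a 1.2-fold higher number from compound 1 to compound 3 (0.07 log units; within the scatter), so all three compounds remain inside the scatter of one another, and neither group on that oxygen stands apart from the hydrogen. Nothing on hand explains these readings. Still open, on these data alone, is whether an amine or a carboxylic acid on a longer chain at this carbonyl carbon would give a step beyond the scatter.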